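The source may report more compounds than this note shows. Statements on the series, on what has been measured and on what is new or still open speak of the compounds shown alone.

Of the compounds shown here, three built on one shared core have been measured in a functional assay on Ehrlich cells (Mus musculus) for antiproliferative activity, read by trypan blue exclusion, with a stated time of 2 h, tested at 25 ug/mL; on this read-out lower numbers stand for a weaker effect and higher numbers for a stronger effect at the one concentration tested. Compound 1 `COc1ccc(C2C(C#N)=C(N)N(c3ccc(S(N)(=O)=O)cc3)C3=C2C(=O)CCC3)cc1` gives 50%. Compound 2 `N#CC1=C(N)N(c2ccc(S(N)(=O)=O)cc2)C2=C(C(=O)CCC2)C1c1ccc([N+](=O)[O-])cc1` gives 80%, and compound 3 `Cc1ccoc1C1C(C#N)=C(N)N(c2ccc(S(N)(=O)=O)cc2)C2=C1C(=O)CCC2` gives 10%. Compound 2 stands highest of the three numbers: the nearest is compound 1, as a number 30 percentage points higher from compound 1 to compound 2 (beyond the scatter), and the furthest is compound 3.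

Compound 4 `N#CC1=C(N)N(c2ccc(S(N)(=O)=O)cc2)C2=C(C(=O)CCC2)C1c1cccs1` has not yet been measured. It is reached from compound 2 by one change: thiophen-2-yl in place of 4-nitrophenyl on a saturated ring carbon.

Among the compounds with values here, two measured steps bear on this change; each also puts a five-membered aromatic ring with one hetero atom in place of a six-membered aromatic ring of carbon only on the same saturated ring carbon. The number fell by a large amount, a number 70 percentage points lower from compound 2 to compound 3 (beyond the scatter), and it fell again, a number 40 percentage points lower from compound 1 to compound 3 (beyond the scatter). Thiophen-2-yl is such a five-membered ring as well, so a drop beyond the scatter, in the same downward direction and of a large size, is expected here. The step is therefore estimated as a number 55 percentage points lower from compound 2 to compound 4 (beyond the scatter). Compound 4 is expected to give 25%, within a range from 5% to 50%.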

Compound 4, a percentage reported as activity, at one concentration (the size of the read-out at that concentration, not a potency): 80%
Beside the measured number, compound 4's estimate is 55 percentage points below it, and the stated range ends below it.
By their numbers in this assay, from the lowest: compound 3; then compound 1; then compounds 2 and 4 (each within the scatter of the next).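

In this assay, compound 4 shows that a five-membered aromatic ring with one hetero atom on this saturated ring carbon can match 4-nitrophenyl, with no change at the digits printed from compound 2 to compound 4 (within the scatter). The same group also separates clearly from the other two substituents, with a number 30 percentage points higher from compound 1 to compound 4 (beyond the scatter) and a number 70 percentage points higher from compound 3 to compound 4 (beyond the scatter), so the low number for compound 3 cannot be read as a general result of placing any five-membered aromatic ring here, and the position distinguishes between two such rings. No measurement at hand explains why thiophen-2-yl and 3-methylfuran-2-yl differ so widely.

Thiophen-2-yl and 3-methylfuran-2-yl differ both in the ring hetero atom and in the methyl group, so the compounds shown leave open which of the two matters; an unsubstituted furan-2-yl or a 3-methylthiophen-2-yl group on this carbon would separate them. From the compounds shown here alone, it also remains open whether an aromatic ring is needed here at all, which a cyclohexyl group or a longer chain such as n-butyl on the same carbon would test.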